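Working notes: 5-ethylfuran-2-yl for 5-ethylthiophen-2-yl

The source may report more compounds than this note shows. Statements on the series, on what has been measured and on what is new or still open speak of the compounds shown alone.

Of the compounds shown here, two have been measured in a functional assay on the whole organism (6C3HED cells, Mus musculus) for inhibition, at a dose of 150 mg/kg by the oral route; a higher number here means more inhibition at the dose given (going by the name of the read-out), a lower number less inhibition. Compound 1 `O=C(Nc1ccc(Cl)cc1)NS(=O)(=O)c1cccs1` gives 16%. For the measured compounds named here, compound 2 `CCc1ccc(S(=O)(=O)NC(=O)Nc2ccc(Cl)cc2)s1` gives 57% and thus stands highest of the two numbers, with compound 1 as its only neighbour, well beyond the scatter. Going by the values given here, the single measured step, a number 41 percentage points higher from compound 1 to compound 2 (beyond the scatter), concerns an ethyl in place of hydrogen on an aromatic carbon.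

Compound 3 `CCc1ccc(S(=O)(=O)NC(=O)Nc2ccc(Cl)cc2)o1` is not yet measured. It differs from compound 2 in one place: 5-ethylfuran-2-yl in place of 5-ethylthiophen-2-yl on a sulfonyl sulfur. The ethyl group is kept in compound 3; what changes is the five-membered aromatic ring that carries it, 5-ethylthiophen-2-yl giving way to 5-ethylfuran-2-yl on the sulfonyl sulfur. Among the compounds with values here, no measured step covers a change of this kind, and the step from compound 1 to compound 2 speaks to the ethyl group, not to the ring. The numbers give no basis for expecting a step beyond the scatter in either direction. Compound 3 is expected to give about 50%, in a range from 25% to 75%. The expected step in this assay, a number 7 percentage points lower from compound 2 to compound 3 (within the scatter), is therefore small, with a wide range since nothing measured bears on the exchange.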

Compound 3, a percentage reported as inhibition, in the whole organism at one dose (the size of the read-out at that dose, not a potency): 57%
Beside the measured number, compound 3's estimate is 7 percentage points below it; the measured number falls inside the stated range.
By their numbers in this assay, from the lowest: compound 1; then compounds 2 and 3 (each within the scatter of the next).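

In this assay the ring exchange on the sulfonyl sulfur shows no change at the digits printed from compound 2 to compound 3 (within the scatter) and so gives no measurable separation between 5-ethylfuran-2-yl and 5-ethylthiophen-2-yl, two groups with the same count of heavy atoms that differ in one ring atom, oxygen for sulfur. The exchange of thiophen-2-yl for 5-ethylfuran-2-yl shows a number 41 percentage points higher from compound 1 to compound 3 (beyond the scatter) and matches in size the earlier a number 41 percentage points higher from compound 1 to compound 2 (beyond the scatter) step, so the higher number reached with the ethyl-bearing thiophene is not confined to that ring and is also reached with an ethyl-bearing furan. No measurement at hand accounts for the two rings reading alike or for the rise from the unsubstituted thiophene.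

Still open, from the compounds shown here alone, is how much of the rise belongs to the ethyl group and how much to the ring, a question that furan-2-yl without any ethyl group would address at this place on the sulfonyl sulfur. Also open, going by these compounds, is whether a methyl group or a longer chain such as propyl or butyl in place of ethyl would keep the inhibition in this assay on either ring.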